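This account rests on a few compounds, and the source may have more. Where it says the series, first, only, none or still open, it means among the compounds named here.

Measured in a functional assay on the whole organism (spleen, spleen) with Rattus norvegicus as the target; on this read-out higher numbers stand for an effect only at larger amounts of compound and lower numbers for an effect already at smaller amounts:
compound 1 `CCCCCCCOc1ccc(CCC(N)(CO)CO)cc1`: 0.049 mg/kg
compound 2 `CCCCCCCOc1ccc(CCC(N)(CO)CCO)cc1`: 0.038 mg/kg
compound 3 `CCCCCCCCc1ccc(CCC(N)(CO)CCO)cc1`: 0.009 mg/kg

Compound 2 differs from compound 1 by hydroxymethyl in place of hydroxy on a saturated chain carbon, two bonds along the chain from an amine nitrogen, and this step reads a 1.3-fold lower number from compound 1 to compound 2 (0.11 log units; within the scatter). Compound 3 gives the lowest number of the three; the difference between its core and the core of compound 1 is not broken down here.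

Compound 4 `CCCCCCCCc1ccc(CCC(N)(CO)CCCO)cc1` is not yet measured. It differs from compound 3 by hydroxymethyl in place of hydroxy on a saturated chain carbon, three bonds along the chain from an amine nitrogen. This is the same kind of change as that from compound 1 to compound 2, but not the same: there the place is two bonds along the chain from an amine nitrogen, here it is three bonds along the chain from an amine nitrogen. Compound 4 is expected to move little, a 1.1-fold higher number from compound 3 to compound 4 (0.05 log units; within the scatter), because the earlier step was a 1.3-fold lower number from compound 1 to compound 2 (0.11 log units; within the scatter). Compound 4 is therefore estimated at 0.01 mg/kg, with a range from 0.004 mg/kg to 0.025 mg/kg.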

Compound 4, dose for 50% inhibition: 0.085 mg/kg
The estimate for compound 4 lay 8.5-fold (0.93 log units) below the measured number; the whole stated range lies below it.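

In this assay the new step reads a 9.4-fold higher number from compound 3 to compound 4 (0.98 log units; beyond the scatter), so hydroxymethyl in place of hydroxy cannot be carried between cores in this series as a fixed increment. The two readings of the change disagree: the same change on two cores in this assay, a 1.3-fold lower number (0.11 log units; within the scatter) from compound 1 to compound 2 and a 9.4-fold higher number (0.98 log units; beyond the scatter) from compound 3 to compound 4, 12-fold (1.09 log units) apart, beyond the scatter of two such steps
This does not show that the core alone sets the gap: the place also differs, two bonds along the chain from an amine nitrogen in one step and three in the other, and each reading rests on a single pair.

Still open, as far as these compounds go, is how the 3-hydroxypropyl group reads on the core of compound 1. Also open, from the compounds shown here alone, is whether an amine or a carboxylic acid in place of its hydroxy, or a longer chain, follows the same trend.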